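The source may report more compounds than this note shows. Statements on the series, on what has been measured and on what is new or still open speak of the compounds shown alone.

Within the data shown here, compound 1 `Oc1nc(NCC2CCCCC2)nc2ccc(Cl)cc12` is one of two compounds measured in a functional assay on the whole organism (uterus) with Rattus norvegicus as the target, tested at 10 uM (on this read-out higher numbers stand for a weaker effect at the one concentration tested and lower numbers for a stronger effect), and in this assay compound 1 gives 86%, the lower of the two numbers. Compound 2 `C[C@@H](Nc1nc(O)c2cc(Cl)ccc2n1)C1CCCCC1` differs from it by a methyl in place of hydrogen on a saturated chain carbon bound to a nitrogen on an aromatic ring and a saturated ring carbon; in this assay compound 2 gives 108%, and the step of a number 22 percentage points higher from compound 1 to compound 2 (beyond the scatter) is modest but beyond the scatter. Compound 3 `Oc1nc(NCC2CCCCC2)nc2ccc(I)cc12` has not yet been measured. It differs from compound 1 as follows: iodo in place of chloro on an aromatic carbon. Among the measured compounds shown here, the one measured step concerns the chain methyl, not the halogen on the aromatic carbon, so no measured step bears on this change. With nothing in the measured pairs to point either way, the analyst expects no step beyond the scatter, no change at the digits printed from compound 1 to compound 3 (within the scatter). For compound 3 in this assay the estimate is 86%, within a range from 66% to 106%.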

Compound 3, a percentage reported as activity, at one concentration (the size of the read-out at that concentration, not a potency): 96.8%
The estimate for compound 3 lay 10.8 percentage points below the measured number; measured number inside the range.
By their numbers in this assay, from the lowest: compound 1; then compound 3; then compound 2.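

In this assay, the halogen on this aromatic carbon proves not to be a silent position: iodo in place of chloro gives a number 10.8 percentage points higher from compound 1 to compound 3 (beyond the scatter), a modest step but beyond the scatter. So far only the chain methyl had been seen to move the read-out, with a number 22 percentage points higher from compound 1 to compound 2 (beyond the scatter), and this second change in the core of compound 1 moves it the same way, towards a weaker effect at the one concentration tested. Nothing available here accounts for the shift between chloro and iodo.

The compounds shown leave open whether a bromo or fluoro group, or a methoxy group, on this aromatic carbon would fall near chloro or near iodo. They also leave open what a hydrogen there would give, and so whether chloro itself contributes to the lower number of compound 1.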